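The compounds below may be only part of what the source reports. "The series", "measured", "known", "first", "only" and "open" are said of these compounds alone.

Of the compounds shown here, two have so far been tested in an assay (Cricetulus griseus) for inhibition of aldehyde dehydrogenase, mitochondrial (Homo sapiens); on this read-out higher numbers stand for weaker inhibition and lower numbers for stronger inhibition. Compound 1 `CCOC(=O)CCCCCOc1ccc2c(=O)c(-c3ccc(O)cc3)coc2c1` gives 280 nM. Compound 2 `CC(Oc1ccc2c(=O)c(-c3ccc(O)cc3)coc2c1)C(=O)O` gives 2500 nM, the higher of the two numbers, and its gap to compound 1 lies beyond the usual scatter. Compound 3 `NCCCCOc1ccc2c(=O)c(-c3ccc(O)cc3)coc2c1` has not been measured; it differs from compound 2 by 4-aminobutyl in place of 1-carboxyethyl on an oxygen on an aromatic ring. Going by the values given here, no measured pair shows this exact change. Since compound 2 gives 2500 nM and compound 1 gives 280 nM, the step is expected to be a 4.2-fold lower number from compound 2 to compound 3 (0.62 log units; beyond the scatter) toward stronger inhibition. Compound 3 is therefore estimated at 600 nM, within 150 nM to 2500 nM.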

Compound 3, half-maximal inhibitory concentration: 250 nM
The estimate for compound 3 lay 2.4-fold (0.38 log units) above the measured number; the measured number falls inside the stated range.
By their numbers in this assay, from the lowest: compounds 3 and 1 (each within the scatter of the next); then compound 2.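

In this assay, 4-aminobutyl in place of 1-carboxyethyl on an oxygen on an aromatic ring gives a 10-fold lower number from compound 2 to compound 3 (1.00 log units; beyond the scatter), although both groups hold the same count of heavy atoms. Amino in place of (ethoxycarbonyl)methyl on a saturated chain carbon, four bonds along the chain from an oxygen on an aromatic ring, gives a 1.1-fold lower number from compound 1 to compound 3 (0.05 log units; within the scatter), so these two chain ends read alike here. Nothing at hand accounts for either step. Open, from the compounds shown here alone, is whether a butyl chain ending in a carboxylic acid would read like compound 2 or compound 3, which would separate chain from end group. Going by these compounds, how a shorter aminoalkyl chain or a terminal amide would read also stays open.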